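The source may report more compounds than this note shows. Statements on the series, on what has been measured and on what is new or still open speak of the compounds shown alone.

Measured compounds in an assay on isolated protein for agonist activity at Free fatty acid receptor 1 (Homo sapiens); a higher number here means that more compound is needed for the effect, a lower number that less compound is needed:
- compound 1 `CC#CC(CC(=O)O)c1ccc(OCc2ccn3cc(-c4ccc(C)cc4C)nc3c2)cc1` gives 503 nM
- compound 2 `CC#CC(CC(=O)O)c1ccc(OCc2ccn3cc(-c4ccc(C(C)C)cc4)nc3c2)cc1` gives 615 nM

Compound 2 carries the higher of the two numbers, but its nearest neighbour is compound 1, and the step of a 1.2-fold higher number from compound 1 to compound 2 (0.09 log units; within the scatter) means the two values cannot be separated. Among the measured compounds shown here, the only measured step therefore tells that exchanging one aryl group for another on this aromatic carbon left the read-out unchanged within the scatter.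

The next step leads to compound 3 `CC#CC(CC(=O)O)c1ccc(OCc2ccn3cc(-c4cccc(C)c4)nc3c2)cc1`. The change is 3-methylphenyl in place of 4-isopropylphenyl on an aromatic carbon. For the measured compounds named here, no measured compound carries a 3-methylphenyl group, so nothing directly reports on it; the single step from compound 1 to compound 2 is the only evidence bearing on this position, and it was flat. On that basis the number for compound 3 in this assay is expected to stay close to that of compound 2, with a step of a 1.0-fold lower number from compound 2 to compound 3 (0.01 log units; within the scatter) that is not expected to reach beyond the scatter. The estimate for compound 3 is 600 nM, with a range from 250 nM to 1500 nM.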

Compound 3, half-maximal effective concentration: 1510 nM
The estimate for compound 3 lay 2.5-fold (0.40 log units) below the measured number; the measured number lies above the stated range.
By their numbers in this assay, from the lowest: compounds 1 and 2 (each within the scatter of the next); then compound 3.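

In this assay, this aromatic carbon of the five-membered aromatic ring no longer looks indifferent to the choice of aryl group: 3-methylphenyl gives a 2.5-fold higher number from compound 2 to compound 3 (0.39 log units; beyond the scatter) and a 3.0-fold higher number from compound 1 to compound 3 (0.48 log units; beyond the scatter), both modest but beyond the scatter, whereas 4-isopropylphenyl and 2,4-dimethylphenyl could not be separated. The flat first step therefore held only for that pair, and the two groups with a 4-substituent both stand apart from 3-methylphenyl, which has none; with three compounds, this is an observation about these groups only and not a general pattern. No available evidence accounts for the higher number of compound 3.

As far as these compounds go, what remains open is whether the difference follows from the presence of the 3-methyl group or from the absence of a 4-substituent, since compound 3 differs from compound 2 in both respects. A 4-methylphenyl group and an unsubstituted phenyl group at this carbon would separate the two readings, while a 4-methoxyphenyl group would test whether the 4-substituent has to be a plain hydrocarbon.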